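Extending the Side Chain of Compound 2 by One Carbon

The source may report more compounds than this note shows. Statements on the series, on what has been measured and on what is new or still open speak of the compounds shown alone.

Measured so far in a functional assay on MCF7 cells (Homo sapiens) for cytotoxicity, read by MTT assay, with a stated time of 72 h; a lower number here means a stronger inhibitor of growth, a higher number a weaker inhibitor of growth:
compound 1 `CSc1nc(NCCCCCO)c2ccccc2n1` — > 100000 nM
compound 2 `CSc1nc(NCCCc2ccccc2)c2ccccc2n1` — > 100000 nM
compound 3 `CCCCC[Se]c1nc(NCc2ccc(SC)cc2)c2ccccc2n1` — 65000 nM

Compound 1 gives a value, > 100000 nM, that is a limit of the assay, not a number. Compound 2 gives a value, > 100000 nM, that is likewise a limit. Compound 3, which carries a different group on the shared core, is the only one of the three with a measured number, 65000 nM. Compound 2 therefore stands at the weakest end of what this assay can report, with no number of its own.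

Within the data shown here, the one step that joins two of the measured compounds, a step that the two limits leave unreadable from compound 1 to compound 2, cannot be read because both of its ends sit at the limit of > 100000 nM in this assay, at which 2 of the 3 values shown sit. Compound 4 `CSc1nc(NCCCCc2ccccc2)c2ccccc2n1` differs from compound 2 by benzyl in place of phenyl on a saturated chain carbon, three bonds along the chain from a nitrogen on an aromatic ring. Among the measured compounds shown here, no measured step bears on that change, and compound 3 differs from compound 4 in more than one place, so it offers no comparison. For the measured compounds named here, the only guide is where compound 2 stands. Compound 4 is therefore expected to remain near the limit, with an estimated value of 100000 nM and a range from 40000 nM to 300000 nM. The expected step of a number no higher from compound 2 to compound 4 (the limit leaves the size open) is none beyond the scatter.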

Compound 4, concentration for total growth inhibition: 64000 nM
The estimate for compound 4 lay 1.6-fold (0.19 log units) above the measured number, within the range that was stated.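

In this assay, among these compounds, compound 4 gives 64000 nM, the only measured number, and not a limit, among compound 1, compound 2 and compound 4, which differ only in the side chain. The readable steps are an at least 1.5-fold lower number from compound 2 to compound 4 (0.19 log units; that floor lies within the scatter) and an at least 1.5-fold lower number from compound 1 to compound 4 (0.19 log units; that floor lies within the scatter), so neither shows a change beyond the scatter, and neither rules one out. Both are floors and not sizes because one end of each sits at a limit: the limit of > 100000 nM in this assay, at which 2 of the 4 values shown sit.

The compounds shown leave open whether a longer chain carrying the phenyl, or an amine or a carboxylic acid at the end of the side chain, would move the number further in this assay. From the compounds shown here alone, how far compound 2 really lies from compound 4 also stays unknown, as compound 2 has only a limit and no number of its own.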